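The source may hold more compounds than are shown below. What is called first, only, known or untested is meant among the compounds shown, and "the series" means these compounds.

Compound 1 `COC(=O)C1=C(C)N=C(C)/C(=C(/O)OC)C1c1cccc(N/C(=N/CCNC2CCN(c3ccccc3)CC2)NC#N)c1` gives 10 nM in an assay on SK-N-MC cells for inhibition of Neuropeptide Y receptor type 1 (Homo sapiens); on this read-out lower numbers stand for stronger inhibition and higher numbers for weaker inhibition. Compound 2 `COC(=O)C1=C(C)N=C(C)/C(=C(/O)OC)C1c1cccc(N/C(=N/CCNC2CCN(c3ccccc3C(F)(F)F)CC2)NC#N)c1` gives 14 nM. Compound 3 `COC(=O)C1=C(C)N=C(C)/C(=C(/O)OC)C1c1cccc(N/C(=N/CCNC2CCN(c3cccc(Cl)c3)CC2)NC#N)c1` gives 8 nM.

Compound 3 has the lowest of the three numbers, yet its steps to the others, a 1.3-fold lower number from compound 1 to compound 3 (0.10 log units; within the scatter) and a 1.8-fold lower number from compound 2 to compound 3 (0.24 log units; within the scatter), both stay within the scatter, so no ordering can be read from them. Compound 4 `COC(=O)C1=C(C)N=C(C)/C(=C(/O)OC)C1c1cccc(N/C(=N/CCNC2CCN(c3ccccc3SC)CC2)NC#N)c1` differs from compound 3 by 2-(methylsulfanyl)phenyl in place of 3-chlorophenyl on an amine nitrogen in a ring. Going by the values given here, the steps that bear on this change are those swapping substituents on that phenyl ring: a 1.4-fold higher number from compound 1 to compound 2 (0.15 log units; within the scatter), a 1.3-fold lower number from compound 1 to compound 3 (0.10 log units; within the scatter) and a 1.8-fold lower number from compound 2 to compound 3 (0.24 log units; within the scatter), all within the scatter. Compound 4 is therefore expected to show no step beyond the scatter, about a 1.3-fold higher number from compound 3 to compound 4 (0.10 log units; within the scatter). The estimate for compound 4 in this assay is 10 nM, with a range from 4 nM to 25 nM.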

Compound 4, half-maximal inhibitory concentration: 3 nM
Beside the measured number, compound 4's estimate is 3.3-fold (0.52 log units) above it; measured number outside the range, below it.
By their numbers in this assay, from the lowest: compound 4; then compounds 3, 1 and 2 (each within the scatter of the next).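

Until now, no swap on the phenyl ring on the amine nitrogen had moved the number beyond the scatter. In this assay, going by these compounds alone, there is a 2.7-fold lower number from compound 3 to compound 4 (0.43 log units; beyond the scatter) and a 3.3-fold lower number from compound 1 to compound 4 (0.52 log units; beyond the scatter) and also a 4.7-fold lower number from compound 2 to compound 4 (0.67 log units; beyond the scatter) in this series, so 2-(methylsulfanyl)phenyl is the first group here to stand apart. The step from 2-(trifluoromethyl)phenyl shows that the identity of the group matters, not merely the presence of a substituent on the ring. No available evidence explains this difference. From the compounds shown here alone, whether 2-methoxyphenyl or 3-(methylsulfanyl)phenyl would match compound 4 remains open.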